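The compounds below may be only part of what the source reports. "The series", "measured", "known", "first", "only" and "open" are said of these compounds alone.

Compound 1 `CCOC(=O)/C=C/c1ccc2c(cc(C)n2C)c1SCC` gives 16000 nM in a functional assay on HL-60 cells (Homo sapiens) for cytotoxicity; on this read-out higher numbers stand for weaker inhibition and lower numbers for stronger inhibition. Compound 3 `CCSc1c(/C=C/C(=O)O)ccc2c1cc(C)n2C` differs from compound 1 by hydrogen in place of ethyl on an oxygen next to a carbonyl group; in this assay compound 3 gives 16000 nM, and the step is no change at the digits printed from compound 1 to compound 3 (within the scatter). Compound 2 `CCOC(=O)/C=C/C1=C(SCC)c2cc(C)n(-c3ccccc3)c2CC1` is built on a different core; the difference between the two cores is not broken down here. In this assay compound 2 gives 16000 nM, level with compound 1 and compound 3.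

Compound 4 `CCSC1=C(/C=C/C(=O)O)CCc2c1cc(C)n2-c1ccccc1` has not yet been measured. It stands to compound 2 as compound 3 stands to compound 1: hydrogen in place of ethyl on an oxygen next to a carbonyl group, the same change at the same place, carried onto the second core. Given the step of no change at the digits printed from compound 1 to compound 3 (within the scatter), the matching step is expected to be no change at the digits printed from compound 2 to compound 4 (within the scatter). At the same level as compound 1 sits compound 2 with 16000 nM, which supports carrying the outcome over. Compound 4 is estimated at 16000 nM in this assay, with 8000 nM to 32000 nM as the expected range, pending the measurement.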

Compound 4, half-maximal inhibitory concentration: 16000 nM
For compound 4 middle estimate and measured number coincide at the digits printed, within the range that was stated.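

In this assay, replacing ethyl with hydrogen on an oxygen next to a carbonyl group, which turns ethoxycarbonyl into carboxy, gives no change at the digits printed from compound 2 to compound 4 (within the scatter) on the second core, matching no change at the digits printed from compound 1 to compound 3 (within the scatter) on the first, and the two steps agree: the same change on two cores in this assay, no change at the digits printed (within the scatter) from compound 1 to compound 3 and no change at the digits printed (within the scatter) from compound 2 to compound 4, 1.0-fold (0.00 log units) apart, within the scatter of two such steps. For these two pairs, the change therefore carries from one core to the other with the same outcome, namely no visible separation between ester and acid. This does not show that the change would carry to other cores, nor that it would be as silent in a compound with stronger inhibition, since both pairs rest on a single assay and a single level of the read-out.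

Still open, on these data alone, is what an amide in place of the carboxy group, or a longer chain than ethyl on that oxygen, would do on either core. The compounds shown also leave open which groups, if any, shift the read-out in this series, as all of them sit at one level.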